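A few compounds are considered here, and "the series" means these few. Any claim that something is new, unique, unknown or untested is made for them only; others in the source may bear on it.

Within the data shown here, compound 1, `O=C(Nc1cccc(-n2cc(-c3ccncc3)c(-c3cc(O)cc(Cl)c3)n2)c1)Nc1ccc(Cl)c(Cl)c1`, is one of only two compounds so far measured in a functional assay on SF-295 cells (Homo sapiens) for inhibition, read by sulforhodamine B assay, with a stated time of 48 h, tested at 1 uM; on this read-out higher numbers stand for a weaker effect at the one concentration tested and lower numbers for a stronger effect. In this assay compound 1 gives 77%, the higher of the two numbers. The other measured compound is compound 2, `COc1cc(Cl)cc(-c2nn(-c3cccc(NC(=O)Nc4cc(C(F)(F)F)cc(C(F)(F)F)c4)c3)cc2-c2ccncc2)c1`; in this assay compound 2 gives 12%, a far lower number, and the gap between the two lies well beyond the usual scatter. Compound 2 differs from compound 1 in more than one place, so the two values alone cannot be split among the separate differences.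

The unmeasured compound 3, `COc1cc(Cl)cc(-c2nn(-c3cccc(NC(=O)Nc4ccc(Cl)c(Cl)c4)c3)cc2-c2ccncc2)c1`, differs from compound 1 in a single place: methyl in place of hydrogen on an oxygen on an aromatic ring. The rest of the shared core is unchanged. Among the measured compounds shown here, no measured pair shows this change on its own, so the size of its effect is open. Compound 2 also carries the methoxy group and gives a much lower number, yet it differs elsewhere too, so that value is only a loose hint. The expected step is a number 27 percentage points lower from compound 1 to compound 3 (beyond the scatter), toward a stronger effect, with wide uncertainty. Compound 3 is estimated to give 50% in this assay, with a likely range from 15% to 85%.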

Compound 3, a percentage reported as activity, at one concentration (the size of the read-out at that concentration, not a potency): 70%
The estimate for compound 3 lay 20 percentage points below the measured number, within the range that was stated.
By their numbers in this assay, from the lowest: compound 2; then compounds 3 and 1 (each within the scatter of the next).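

Replacing the hydrogen on the oxygen with methyl, hydroxy to methoxy, gives a number 7 percentage points lower from compound 1 to compound 3 (within the scatter) in this assay, so at this position, at the single concentration tested, the two groups cannot be told apart. The methoxy group alone also does not bring a number as low as that of compound 2: compound 3 gives 70% and compound 2 gives 12% even though both carry methoxy, and these two compounds differ in one place, the substituted phenyl group on the urea, which bears chlorines in compound 3 and trifluoromethyl groups in compound 2. No measurement of any other kind is at hand to explain this result.

From the compounds shown here alone, whether a larger group on this oxygen, such as ethoxy or a longer chain, or an amine in place of the hydroxy, would leave the number just as unchanged remains open. Also open, going by these compounds, is whether hydroxy and methoxy would still match when the trifluoromethyl-bearing group of compound 2 sits on the urea.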